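Adding a Second Methoxy: From Compound 2 to Compound 3

The source may report more compounds than this note shows. Statements on the series, on what has been measured and on what is new or still open speak of the compounds shown alone.

Compound 1 `COc1ccc(Cn2cc(CNC(=O)c3cn(-c4ccccc4)nc3-c3ccc(F)cc3)nn2)cc1OC` reaches only the limit of > 100000 nM in a functional assay on MIA PaCa-2 cells (Homo sapiens) for antiproliferative activity, read by sulforhodamine B assay, with a stated time of 48 h; a higher number here means a weaker inhibitor of growth, a lower number a stronger inhibitor of growth. Within the data shown here, compound 2 `COc1ccc(Cn2cc(CNC(=O)c3cn(-c4ccccc4)nc3-c3ccc(OC)cc3)nn2)cc1` gives 2500 nM in this assay, the only actual number among the two results. Compound 3 `COc1ccc(-c2nn(-c3ccccc3)cc2C(=O)NCc2cn(Cc3ccc(OC)c(OC)c3)nn2)cc1` carries methoxy in place of hydrogen on an aromatic carbon, turning 4-methoxyphenyl into 3,4-dimethoxyphenyl. Among the measured compounds shown here, no measured pair shows this change, so the step from compound 2 to compound 3 is expected to stay within the usual scatter, with no clear direction. Compound 3 is therefore estimated at 3000 nM in this assay, expected between 800 nM and 12000 nM, an expected step of a 1.2-fold higher number from compound 2 to compound 3 (0.08 log units; within the scatter).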

Compound 3, concentration for 50% growth inhibition: 16300 nM
Beside the measured number, compound 3's estimate is 5.4-fold (0.74 log units) below it; the measured number lies above the stated range.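

Turning 4-methoxybenzyl into 3,4-dimethoxybenzyl gives the first readable step at this position in this assay, and it weakens growth inhibition: a 6.5-fold higher number from compound 2 to compound 3 (0.81 log units; beyond the scatter) is what the added methoxy costs. With 3,4-dimethoxybenzyl kept, methoxy in place of fluoro on the other aromatic ring gives an at least 6.1-fold lower number from compound 1 to compound 3 (0.78 log units; beyond the scatter) as a bound only. Compound 1 stands at a limit of the assay, not at a number: the limit of > 100000 nM in this assay, at which 1 of the 3 values shown sits.

Going by these compounds, whether a hydroxyl, a chloro or an amine at this position would fare better than methoxy stays open. So does whether a longer ether chain there would weaken growth inhibition as much.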